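Working notes: acylating the free hydroxy of compound 2

The source may hold more compounds than are shown below. What is called first, only, known or untested is meant among the compounds shown, and "the series" means these compounds.

Measured so far:
- compound 1 `COC(=O)C1=CO[C@@H](O[C@@H]2O[C@H](COC(c3ccccc3)(c3ccccc3)c3ccccc3)[C@@H](OC(=O)O)[C@H](OC(C)=O)[C@H]2OC(C)=O)[C@@H]2[C@@H](C)[C@@H](OC(C)=O)C[C@H]12` gives 2.44 ug/mL
- compound 2 `COC(=O)C1=CO[C@@H](O[C@@H]2O[C@H](CO)[C@@H](OC(C)=O)[C@H](OC(C)=O)[C@H]2OC(C)=O)[C@@H]2[C@@H](C)[C@@H](OC(C)=O)C[C@H]12` gives "not active" (no number reported)
- compound 3 `C=CC(=O)OC[C@H]1O[C@@H](O[C@@H]2OC=C(C(=O)OC)[C@H]3C[C@H](OC(C)=O)[C@H](C)[C@@H]23)[C@H](OC(C)=O)[C@@H](OC(C)=O)[C@@H]1OC(C)=O` gives "not active" (no number reported)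

Not yet measured: compound 4 `COC(=O)C1=CO[C@@H](O[C@@H]2O[C@H](COC(=O)c3cccc([N+](=O)[O-])c3)[C@@H](OC(C)=O)[C@H](OC(C)=O)[C@H]2OC(C)=O)[C@@H]2[C@@H](C)[C@@H](OC(C)=O)C[C@H]12`

In a functional assay on WRL68 cells (Homo sapiens) for cytotoxicity, read by MTT assay, with a stated time of 4 h (on this read-out lower numbers stand for stronger inhibition and higher numbers for weaker inhibition), compound 2 has no number ("not active" (no number reported)), and compound 3 shares that result. Only compound 1 gives a number. The step (3-nitrophenyl)carbonyl in place of hydrogen on an oxygen on a saturated carbon puts (3-nitrophenyl)carbonyl in place of hydrogen on an oxygen on a saturated carbon. A step toward stronger inhibition is expected in this assay, though its size cannot be stated without a number for compound 2. The expectation is tentative: compound 3 ("not active" (no number reported)) shows that another result without a number remains possible. For compound 4 the estimated value is 12 ug/mL, with an expected range of 3 ug/mL to 50 ug/mL.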

Compound 4, half-maximal inhibitory concentration: 3.2 ug/mL
For compound 4 the middle estimate is 3.8-fold (0.57 log units) above the measured one; the range from low to high includes it.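

Compound 4 gives 3.2 ug/mL in this assay and compound 2 has no number there, so no step can be read between them. The compounds shown leave open how much the ((3-nitrophenyl)carbonyl)oxy group contributes to that value. No measured evidence bears on this result.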